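This account rests on a few compounds, and the source may have more. Where it says the series, first, only, none or still open, it means among the compounds named here.

Measured so far in an assay on HEK293 cells for inhibition of Voltage-dependent N-type calcium channel subunit alpha-1B (Homo sapiens), read by fluorescence and calcium flux, with a stated time of 5 min; a higher number here means a weaker inhibitor, a lower number a stronger inhibitor:
compound 1, `COc1ccccc1-n1nc(C2CC(C)(C)OC(C)(C)C2)cc1-c1ccnc(Cl)c1`: 11 nM
compound 2, `COc1ccccc1-n1nc([C@@H]2CCO[C@@H](C(C)C)C2)cc1-c1ccc(Cl)cc1`: 20 nM

In this assay compound 1 gives 11 nM, and compound 2 gives 20 nM. The gap between these two numbers lies within the usual scatter of repeated measurements, so the two compounds cannot be told apart on potency; compound 1 simply stands as one of two closely matched inhibitors. Compound 2 also differs from compound 1 in more than one place, so no single structural step can be read from the pair.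

Compound 3, `CCOc1ccc(-c2cc(C3CC(C)(C)OC(C)(C)C3)nn2-c2ccccc2OC)cn1`, is the next compound to be tested. It differs from compound 1 in one place: 6-ethoxypyridin-3-yl in place of 2-chloropyridin-4-yl on an aromatic carbon. Going by the values given here, with no measured step of this kind to lean on, the expectation rests on the change alone. A larger group enters where a smaller one leaves, and the outcome is uncertain. The step from compound 1 to compound 3 is expected to be small, a 2.3-fold higher number from compound 1 to compound 3 (0.36 log units; beyond the scatter), possibly toward a weaker inhibitor but not clearly beyond the scatter. Compound 3 is therefore estimated to give about 25 nM, in a range from 6 nM to 100 nM.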

Compound 3, half-maximal inhibitory concentration: 5 nM
The estimate for compound 3 lay 5.0-fold (0.70 log units) above the measured number; measured number below the stated range.
By their numbers in this assay, from the lowest: compound 3; then compounds 1 and 2 (each within the scatter of the next).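

The aromatic carbon next to the ring nitrogen of the five-membered ring tolerates more than a single group: in this assay, placing 6-ethoxypyridin-3-yl there instead of 2-chloropyridin-4-yl gives a 2.2-fold lower number from compound 1 to compound 3 (0.34 log units; beyond the scatter), a modest step that is nonetheless beyond the usual scatter. Going by these compounds alone, this is the first single-place comparison, and it shows that the chlorine can be lost and a larger group with an ethoxy chain taken on at this position without any loss of inhibition; the number in fact moves toward a stronger inhibitor. Nothing measured here accounts for the size or direction of this step.

The step changes two things at once, the substituent on the pyridine ring and the ring carbon through which that ring is attached, so the share of each remains unresolved. Still open, from the compounds shown here alone, is how a 6-methoxypyridin-3-yl group, a 6-chloropyridin-3-yl group or a 6-aminopyridin-3-yl group would behave at this position, and whether a longer chain such as propoxy would carry the trend further or reverse it.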